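The compounds below may be only part of what the source reports. "The series", "measured", "known", "first", "only" and "open" are said of these compounds alone.

Two compounds have been measured in an ADME assay on HEL cells (Homo sapiens), read by cell counting, with a stated time of 3 days; a lower number here means that less compound is tolerated, a higher number that more compound is tolerated:

compound 1 `O=c1[nH]c(=O)n([C@H]2C[C@H](O)[C@@H](CO)O2)cc1C#CC#Cc1ccccn1`: 1500 nM
compound 2 `Nc1cccc(C#CC#Cc2cn([C@H]3C[C@H](O)[C@@H](CO)O3)c(=O)[nH]c2=O)c1`: a limit, > 100000 nM

Going by the values given here, compound 1 stands as the only compound with an actual number in this assay; the one further value shown is a limit. Among the compounds with values here, the single measured step, an at least 66-fold higher number from compound 1 to compound 2 (1.82 log units; beyond the scatter), is large and upward, and its size rests on (the limit of > 100000 nM in this assay, at which 1 of the 2 values shown sits).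

Compound 3 `O=c1[nH]c(=O)n([C@H]2C[C@H](O)[C@@H](CO)O2)cc1C#CC#CC1CC1` has not yet been measured. It differs from compound 1 by cyclopropyl in place of pyridin-2-yl on a triple-bonded carbon. Within the data shown here, no measured step covers this exact exchange, so the step from compound 1 to compound 2 is the only guide, and it involves a different incoming group at the same place. It shows that exchanging the group on that triple-bonded carbon can move the number in this assay far beyond the scatter, and in the upward direction. On that basis an upward shift is expected for compound 3 as well, though a smaller one, since the incoming cyclopropyl shares nothing with the 3-aminophenyl of compound 2; the expected step is a 5.3-fold higher number from compound 1 to compound 3 (0.73 log units; beyond the scatter). Compound 3 is accordingly estimated at 8000 nM, within a range from 1500 nM to 100000 nM.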

Compound 3, half-maximal cytotoxic concentration: > 100000 nM
Compound 3 ended at the assay's limit; the forecaster's own chance of this, stated with the estimate: 30%; middle value at least 12-fold (1.09 log units) away from the limit.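

In this assay, the change to cyclopropyl gives an at least 66-fold higher number from compound 1 to compound 3 (1.82 log units; beyond the scatter), so the upward move at this triple-bonded carbon is not tied to the 3-aminophenyl of compound 2, since a three-membered non-aromatic ring of carbon only goes the same way. Among the three compounds, pyridin-2-yl is now the only group on this carbon with an actual number, and compound 1 sits beyond the scatter on the low side of both others, with no compound shown going against this. The value of compound 3 is a limit, as is that of compound 2, so the step between them cannot be read, and the size of each step from compound 1 is only a minimum: the limit of > 100000 nM in this assay, at which 2 of the 3 values shown sit.

Going by these compounds, how far compound 2 and compound 3 lie past that limit stays open, so the two groups cannot be ranked against each other. Also open, on these data alone, is whether the low number of compound 1 goes with the nitrogen of pyridin-2-yl or with the aromatic ring as such, a question that a plain phenyl on the same triple-bonded carbon would address.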